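The source may report more compounds than this note shows. Statements on the series, on what has been measured and on what is new or still open speak of the compounds shown alone.

The measured compounds:

Compound 1 `Clc1ccccc1-c1n[nH]cc1N1CCNCC1` — > 10000 nM
Compound 2 `Clc1ccc(-c2n[nH]cc2N2CCNCC2)cc1` — > 10000 nM
Compound 3 `Fc1ccccc1-c1n[nH]cc1N1CCNCC1` — > 10000 nM

All three were tested in an assay on isolated protein for binding affinity to 5-hydroxytryptamine receptor 1D (Homo sapiens); on this read-out higher numbers stand for weaker inhibition and lower numbers for stronger inhibition. Compound 1 gives > 10000 nM, which is a limit of the assay and not a number. Compound 2 gives > 10000 nM, again a limit rather than a number. Compound 3 gives > 10000 nM, also a limit.

Compound 1 and compound 3 differ in one place, (fluoro in place of chloro on an aromatic carbon), and the step in this assay from compound 1 to compound 3 is a step that the two limits leave unreadable from compound 1 to compound 3. The difference between the core of compound 1 and the core of compound 2 is not broken down here.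

Compound 4 `Fc1ccc(-c2n[nH]cc2N2CCNCC2)cc1` is not yet measured. It differs from compound 2 by fluoro in place of chloro on an aromatic carbon. Among the compounds with values here, this is the same kind of change as the one between compound 1 and compound 3, but not the same change: in compound 3 the fluoro sits ortho to a large group, in compound 4 it sits para to a large group.

What the data offer is the limit of > 10000 nM in this assay, at which 3 of the 3 values shown sit. With every value at that limit, the earlier step gives no size to lean on. The step from compound 2 to compound 4 is therefore expected to be a step that the limit leaves unreadable from compound 2 to compound 4, resting on compound 2 at > 10000 nM. For compound 4 the expected value is 20000 nM, with a range from 8000 nM to 60000 nM, most likely reported as a limit once more.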

Compound 4, inhibition constant: > 10000 nM
Compound 4 gave a limit, no number; the forecaster's own chance of this, stated with the estimate: 85%; the middle value lies beyond the limit too.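

Compound 2 and compound 4 both give only a limit and no number, so the step between them cannot be read and no size can be put on fluoro in place of chloro here: the limit of > 10000 nM in this assay, at which 4 of the 4 values shown sit.

From the compounds shown here alone, still open in this assay is how strongly any of the four compounds binds, and whether fluoro and chloro differ at all within either pair.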